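Pyridin-3-yl for 2-methylphenyl: working notes on compound 4

This account rests on a few compounds, and the source may have more. Where it says the series, first, only, none or still open, it means among the compounds named here.

Values in a functional assay on DU-145 cells (Homo sapiens) for cytotoxicity, read by ELISA, with a stated time of 4 days (on this read-out higher numbers stand for weaker inhibition and lower numbers for stronger inhibition), so far:
- compound 1 `Cc1ccsc1-c1cc(-c2ccco2)cc(-c2ccccc2Cl)n1` gives 29900 nM
- compound 2 `Cc1ccsc1-c1cc(-c2ccoc2)cc(-c2ccco2)n1` gives 30400 nM
- compound 3 `Cc1ccccc1-c1cc(-c2ccoc2)cc(-c2ccc(Cl)s2)n1` gives 18500 nM

Compound 3 stands within the scatter of both compound 1 and compound 2, so the three values form one group with no order among them. Compared with compound 3, compound 4 (`Clc1ccc(-c2cc(-c3ccoc3)cc(-c3cccnc3)n2)s1`) has pyridin-3-yl in place of 2-methylphenyl on an aromatic carbon of the shared core. Going by the values given here, no two measured compounds differ in one place only, so this change has no direct measure. Compound 1 at (29900 nM), compound 2 at (30400 nM) and compound 3 at (18500 nM) carry different groups yet lie within the scatter of each other, so no step beyond the scatter is expected in this assay and no direction can be argued. The expected step is a 1.2-fold higher number from compound 3 to compound 4 (0.08 log units; within the scatter) and it is estimated to stay within the scatter. For compound 4 the estimated value is 22000 nM with an expected range from 9000 nM to 55000 nM on this read-out.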

Compound 4, half-maximal inhibitory concentration: 18500 nM
Beside the measured number, compound 4's estimate is 1.2-fold (0.08 log units) above it; low and high end bracket the measured number.
By their numbers in this assay, from the lowest: compounds 3, 4, 1 and 2 (each within the scatter of the next).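

Going by these compounds alone, the exchange of 2-methylphenyl for pyridin-3-yl, on the aromatic carbon next to the ring nitrogen, is the only single-place comparison so far, and in this assay it reads (no change at the digits printed from compound 3 to compound 4 (within the scatter)). With 5-chlorothiophen-2-yl and furan-3-yl held constant, this position accepts a six-membered aromatic ring with one hetero atom in place of a carbon-only ring, with no shift beyond the scatter. No measurement is available that could explain this result.

As far as these compounds go, only these two six-membered aromatic rings can be compared at this position, so what a morpholine, a primary amine, a carboxylic acid or a longer alkyl chain would give there remains open. Also open, from the compounds shown here alone, is whether pyridin-3-yl reads the same when 5-chlorothiophen-2-yl or furan-3-yl is exchanged elsewhere on the shared core.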